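Replacing the 3-methylbut-2-en-1-yl ether on the shared core

The compounds below may be only part of what the source reports. "The series", "measured", "known", "first", "only" and "open" are said of these compounds alone.

Measured compounds:
compound 1 `CC(C)=CCOc1cc(=O)n(CCCO)c2c1CC(CC=C(C)C)C(C)(C)C2`: 20.7%
compound 2 `COc1ccc(OCCCOc2cc(=O)n(CCCO)c3c2CC(CC=C(C)C)C(C)(C)C3)cc1`: 47.7%

In a functional assay on PANC-1 cells (Homo sapiens) for inhibition, read by MTT assay, with a stated time of 24 h, tested at 10 uM (on this read-out higher numbers stand for more inhibition at the one concentration tested (going by the name of the read-out) and lower numbers for less inhibition), compound 1 gives 20.7% and stands lowest of the two numbers; compound 2 gives 47.7% in this assay. Within the data shown here, the one measured step, a number 27 percentage points higher from compound 1 to compound 2 (beyond the scatter), swaps the chain end for an aryl-bearing piece at a saturated chain carbon. Compound 3 `COc1cccc(NC(=O)Oc2cc(=O)n(CCCO)c3c2CC(CC=C(C)C)C(C)(C)C3)c1` differs from compound 1 in this way: (3-methoxyphenyl)carbamoyl in place of 3-methylbut-2-en-1-yl on an oxygen on an aromatic ring. The change again brings in an aromatic ring where compound 1 carries only the unsaturated chain, but it sits directly on the ring oxygen, so the measured step bears on it only loosely. A modest rise in this assay is expected, of a size near the one seen, though with wide uncertainty. For compound 3 a value of 40% is estimated, within 18% to 62%. The estimated step is therefore a number 19.3 percentage points higher from compound 1 to compound 3 (beyond the scatter).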

Compound 3, a percentage reported as inhibition, at one concentration (the size of the read-out at that concentration, not a potency): 16.2%
Estimate against measurement, compound 3: 23.8 percentage points above; the whole stated range lies above it.
By their numbers in this assay, from the lowest: compounds 3 and 1 (each within the scatter of the next); then compound 2.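

In this assay the exchange gives a number 4.5 percentage points lower from compound 1 to compound 3 (within the scatter) and so does not repeat the gain of a number 27 percentage points higher from compound 1 to compound 2 (beyond the scatter) at this oxygen. An aromatic ring entering on the oxygen on an aromatic ring therefore does not by itself go with a higher number, and the two aryl-bearing groups give different outcomes on the shared core. Nothing measured on these groups accounts for that difference.

Open, going by these compounds, is whether the carbamoyl link or the 3-methoxyphenyl ring decides the outcome, a question that a 3-methoxyphenyl ring on an ether chain or a carbamoyl bearing a simple butyl chain could separate. Also open, on these data alone, is how an amine or a carboxylic acid at the end of a longer ether chain would read at this oxygen.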